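Trifluoromethoxy for iodo: what compound 4 should give

The compounds below may be only part of what the source reports. "The series", "measured", "known", "first", "only" and "open" are said of these compounds alone.

Compound 3 `O=C(C1=C(Nc2ccc(I)cc2)C(=O)N(CCCn2ccnc2)C1c1ccc(Br)cc1)c1ccccc1` gives 23400 nM in a functional assay on SAOS-2 cells (Homo sapiens) for antiproliferative activity, read by MTT assay, with a stated time of 72 h (a higher number here means a weaker inhibitor, a lower number a stronger inhibitor), the second highest of the three numbers in hand. Compound 1 `CC(C)OC1=C(C(=O)c2ccccc2)C(c2ccc(Br)cc2)N(CCCn2ccnc2)C1=O` gives 23000 nM and compound 2 `CCOc1ccc(NC2=C(C(=O)c3ccccc3)C(c3ccc(Br)cc3)N(CCCn3ccnc3)C2=O)cc1` gives 30900 nM; the steps of a 1.0-fold higher number from compound 1 to compound 3 (0.01 log units; within the scatter) and a 1.3-fold lower number from compound 2 to compound 3 (0.12 log units; within the scatter) both lie within the scatter, as does a 1.3-fold higher number from compound 1 to compound 2 (0.13 log units; within the scatter). Compound 4 `O=C(C1=C(Nc2ccc(OC(F)(F)F)cc2)C(=O)N(CCCn2ccnc2)C1c1ccc(Br)cc1)c1ccccc1` differs from compound 3 by trifluoromethoxy in place of iodo on an aromatic carbon. Of the measured steps, a 1.3-fold lower number from compound 2 to compound 3 (0.12 log units; within the scatter) bears most directly on this change, exchanging the group on that aromatic carbon, and it lies within the scatter. The step of a 1.0-fold higher number from compound 3 to compound 4 (0.01 log units; within the scatter) is therefore expected to stay within the scatter as well, in no clear direction. The estimate for compound 4 is 24000 nM, with a range from 12000 nM to 48000 nM.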

Compound 4, half-maximal inhibitory concentration: 17900 nM
Compound 4: middle estimate off by 1.3-fold (0.13 log units), on the high side, within the range that was stated.
By their numbers in this assay, from the lowest: compounds 4, 1, 3 and 2 (each within the scatter of the next).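

In this assay the para position of the aniline ring tolerates a change from one heavy atom to five: trifluoromethoxy in place of iodo gives a 1.3-fold lower number from compound 3 to compound 4 (0.12 log units; within the scatter) and so stays within the scatter. Trifluoromethyl in place of ethyl on the oxygen gives a 1.7-fold lower number from compound 2 to compound 4 (0.24 log units; within the scatter) and the (4-(trifluoromethoxy)phenyl)amino group in place of isopropoxy gives a 1.3-fold lower number from compound 1 to compound 4 (0.11 log units; within the scatter) so neither comparison leaves the scatter either. Nothing available explains these steps.

On these data alone, whether an amine or a carboxylic acid on that aromatic carbon would move the number beyond the scatter remains open.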